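This account rests on a few compounds, and the source may have more. Where it says the series, first, only, none or still open, it means among the compounds named here.

Measured compounds:
- Compound 1 `CC(/N=c1\c(O)c(O)\c1=N/c1cccnc1)C(C)(C)C`: 1950 nM
- Compound 2 `CC(/N=c1\c(O)c(O)\c1=N/c1cncc(Br)c1)C(C)(C)C`: 11700 nM
- Compound 3 `CC(C)(C)/N=c1\c(O)c(O)\c1=N/c1ccc(C#N)cc1`: 560 nM

In a functional assay for inhibition, with Rattus norvegicus as the target (on this read-out higher numbers stand for weaker inhibition and lower numbers for stronger inhibition), compound 3 gives the lowest of the three numbers. Its nearest neighbour on this read-out is compound 1 with 1950 nM, and the furthest is compound 2 with 11700 nM. Among the measured compounds shown here, the only single-point step among the measured compounds, a 6.0-fold higher number from compound 1 to compound 2 (0.78 log units; beyond the scatter), concerns bromo in place of hydrogen on an aromatic carbon and does not touch the group on the double-bonded nitrogen that is changed here.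

Compound 4 `C[C@H](/N=c1\c(O)c(O)\c1=N/c1ccc(C#N)cc1)C1CCCCC1` is the next compound, not yet measured in this assay. It differs from compound 3 as follows: 1-cyclohexylethyl in place of tert-butyl on a double-bonded nitrogen. For the measured compounds named here, no measured step changes this group alone; compound 1 and compound 3 differ at this nitrogen but also on the aromatic ring, so their two values give no clean guide. The expectation therefore rests mainly on compound 3 itself, and a step of a 1.3-fold higher number from compound 3 to compound 4 (0.10 log units; within the scatter) with a wide range is expected, the number estimated at 700 nM with a range from 200 nM to 2500 nM.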

Compound 4, half-maximal inhibitory concentration: > 30000 nM
Compound 4: a limit, no number (the forecaster's own chance of this, stated with the estimate: 3%); at least 42-fold (1.63 log units) between middle value and limit.
By their numbers in this assay, from the lowest: compound 3; then compound 1; then compound 2. At a limit, above all of these: compound 4.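

In this assay, compound 4 gives > 30000 nM, which is a limit of the assay and not a number. Replacing tert-butyl with 1-cyclohexylethyl on the double-bonded nitrogen, with the rest of the structure unchanged, gives an at least 53-fold higher number from compound 3 to compound 4 (1.72 log units; beyond the scatter), so this position does not accept every group made only of carbon and hydrogen. The full size of this step remains unknown: the limit of > 30000 nM in this assay, at which 1 of the 4 values shown sits.

The compounds shown do not separate the contributions of the six-membered ring, the larger group size and the defined stereocentre to this change. Also open, on these data alone, is how the nitrogen position would respond on this scaffold to the opposite stereoisomer, to a smaller group such as cyclopropyl, or to a chain ending in an amine or a carboxylic acid.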